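The source may report more compounds than this note shows. Statements on the series, on what has been measured and on what is new or still open speak of the compounds shown alone.

Measured compounds:
- Compound 1 `COc1ccc(C2C=C(c3cc(OC)c(OC)c(OC)c3)NC(=S)N2)cc1OC` — in a functional assay on B16 cells (Mus musculus) for cytotoxicity, read by MTT assay, with a stated time of 72 h (on this read-out lower numbers stand for stronger inhibition and higher numbers for weaker inhibition), compound 1 reaches only the limit > 100000 nM.
- Compound 2 `COc1ccc(C2C=C(c3cc(OC)c(OC)c(OC)c3)NC(=S)N2)cc1O` — in this assay compound 2 gives 6000 nM.

Among the measured compounds shown here, compound 2 holds the only number; the other entry is a limit of the assay rather than a value, as set out in the limit of > 100000 nM in this assay, at which 1 of the 2 values shown sits. For the measured compounds named here, the one measured step, an at least 16-fold lower number from compound 1 to compound 2 (1.22 log units; beyond the scatter), is large and beyond the scatter.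

Compound 3 `COc1ccc(C2C=C(c3cc(OC)c(OC)c(OC)c3)NC(=S)N2)cc1[N+](=O)[O-]` differs from compound 2 by nitro in place of hydroxy on an aromatic carbon. The step from compound 1 to compound 2 touches the same aromatic carbon but exchanges a different pair of groups, so it bears only indirectly on the present change. Going by the values given here, it does show that the hydroxy group goes with the one number below the limit; compound 3 loses that group and takes a nitro group instead, for which nothing has been measured here. The expectation is therefore a weaker compound than compound 2, with a wide margin in this assay, the expected step being a 6.7-fold higher number from compound 2 to compound 3 (0.82 log units; beyond the scatter). For compound 3 the estimate is 40000 nM, ranging from 6000 nM to 100000 nM, with a real chance that only a limit is reported.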

Compound 3, half-maximal inhibitory concentration: > 100000 nM
Compound 3 was reported as a limit; the forecaster's own chance of this, stated with the estimate: 35%; at least 2.5-fold (0.39 log units) between middle value and limit.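

At this aromatic carbon, ortho to a methoxy group, hydroxy is now the only one of the three groups shown that gives a number in this assay, and nitro in place of hydroxy gives an at least 16-fold higher number from compound 2 to compound 3 (1.22 log units; beyond the scatter). Methoxy and nitro both leave the series at a limit rather than a number, so the step between compound 1 and compound 3 cannot be read and no order can be set between these two groups: the limit of > 100000 nM in this assay, at which 2 of the 3 values shown sit. The change also replaces a group carrying a hydrogen-bond donor with nitro, which has no such donor and more heavy atoms, and the series cannot say which of these differences goes with the loss of a number.

The compounds shown leave open whether a number at this carbon needs the hydroxy group itself or would also appear with another group, such as an amine or a hydroxymethyl group. They also leave open whether hydroxy gives a number at other places on this aromatic ring, and how far compound 1 and compound 3 lie from each other past their shared limit.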